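A few compounds are considered here, and "the series" means these few. Any claim that something is new, unique, unknown or untested is made for them only; others in the source may bear on it.

Compound 1 `O=c1[nH]c(=O)n(CCC(CO)CO)cc1-c1ccco1` carries a furan-2-yl group on the shared core and two free hydroxyls on its side chain. In a functional assay on MCF7 cells (Homo sapiens) for antiproliferative activity, read by MTT assay, with a stated time of 72 h (a lower number here means a stronger inhibitor, a higher number a weaker inhibitor), compound 1 reaches only the limit of the measurement, < 10 nM (the limit of < 10 nM in this assay, at which 1 of the 3 values shown sits). Compound 4 `CCCCCC#Cc1cn(CCC(CO)CO)c(=O)[nH]c1=O` differs from it by hept-1-yn-1-yl in place of furan-2-yl on an aromatic carbon. The other two compounds measured, compound 2 `CCCCCC#Cc1cn(CCC(COC(C)=O)COC(C)=O)c(=O)n(C(=O)c2ccccc2)c1=O` and compound 3 `CC(=O)OCC(CCn1cc(C#CC(C)(C)C)c(=O)n(C(=O)c2ccccc2)c1=O)COC(C)=O`, are weak in this assay, compound 2 giving 62200 nM and compound 3 giving 67100 nM; both carry an alkyne as compound 4 does but also acetyl and benzoyl groups that compound 4 lacks. Among the measured compounds shown here, the only measured step, a 1.1-fold higher number from compound 2 to compound 3 (0.03 log units; within the scatter), swaps one alkyne substituent for another and does not touch the furan-to-alkyne change itself. Compound 4 is therefore expected to lose potency, with an estimated 2000 nM in a range from 50 nM to 50000 nM. This expectation corresponds to a step of an at least 200-fold higher number from compound 1 to compound 4 (2.30 log units; beyond the scatter).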

Compound 4, half-maximal inhibitory concentration: 37800 nM
The estimate for compound 4 lay 19-fold (1.28 log units) below the measured number; low and high end bracket the measured number.
By their numbers in this assay, from the lowest: compounds 4, 2 and 3 (each within the scatter of the next). At a limit, below all of these: compound 1.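

In this assay, an at least 3700-fold higher number from compound 1 to compound 4 (3.57 log units; beyond the scatter), with hept-1-yn-1-yl in place of furan-2-yl on this aromatic carbon, so the group at this position matters greatly with the side chain and the rest of the core unchanged. Among the compounds shown here, the only earlier step exchanged one alkyne substituent for another and never touched the furan-2-yl group. Compound 1 stands at a limit of the assay, so this step gives only a lower bound on the change: the limit of < 10 nM in this assay, at which 1 of the 4 values shown sits.

From the compounds shown here alone, how a phenyl or thiophene ring, or a shorter alkyne chain, would behave at this position remains open. So does whether the furan oxygen itself matters.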